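This account rests on a few compounds, and the source may have more. Where it says the series, first, only, none or still open, it means among the compounds named here.

Compound 3 `CC(C)(C)c1cc(NC(=O)Nc2ccc(-c3cn4cc(F)ccc4n3)cc2)no1` gives the lowest number of the three measured compounds in a functional assay on MV4-11 cells (Homo sapiens) for cytotoxicity, read by MTT assay, with a stated time of 72 h (on this read-out higher numbers stand for weaker inhibition and lower numbers for stronger inhibition), at 20.9 nM. Its nearest neighbour on that read-out is compound 1 `CC(C)(C)c1cc(NC(=O)Nc2ccc(-c3cn4cccnc4n3)cc2)no1`, which in this assay gives 171 nM, a gap beyond the scatter; furthest away stands compound 2 `Cc1cccn2cc(-c3ccc(NC(=O)Nc4cc(C(C)(C)C)on4)cc3)nc12`, which in this assay gives 248 nM, also beyond the scatter. No two of the measured compounds differ in only one place, so no isolated step can be read from them. Compound 4 `CC(C)(C)c1cc(NC(=O)Nc2ccc(-c3cn4cc(C5CC5)ccc4n3)cc2)no1` has not yet been measured; it differs from compound 3 in one place: cyclopropyl in place of fluoro on an aromatic carbon. The measured set says nothing about exchanging fluoro for cyclopropyl on that aromatic carbon, so the expectation rests on the change itself. The estimated step of a 1.9-fold higher number from compound 3 to compound 4 (0.28 log units; within the scatter) is expected to be small, close to the scatter, with a slight weakening if any. Compound 4 is therefore estimated at 40 nM, with a range from 10 nM to 160 nM.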

Compound 4, half-maximal inhibitory concentration: 15.8 nM
Beside the measured number, compound 4's estimate is 2.5-fold (0.40 log units) above it, within the range that was stated.
By their numbers in this assay, from the lowest: compounds 4 and 3 (each within the scatter of the next); then compounds 1 and 2 (each within the scatter of the next).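

In this assay, cyclopropyl in place of fluoro on this aromatic carbon gives a 1.3-fold lower number from compound 3 to compound 4 (0.12 log units; within the scatter) and so leaves the two groups indistinguishable on this read-out. Among these compounds, the position, para to a fused ring, therefore takes a group of 3 heavy atoms with a three-membered ring in place of a single fluorine while the number stays within the scatter, something the earlier compounds, none differing in only one place, could not show. Nothing at hand explains why the two groups read alike.

Going by these compounds, whether an amine, a carboxylic acid, a longer alkyl chain or plain hydrogen would read the same on this carbon remains open. Compound 1 and compound 2 differ from compound 3 in more than one place, so no further steps can be read from them.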